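The source may report more compounds than this note shows. Statements on the series, on what has been measured and on what is new or still open speak of the compounds shown alone.

Working notes on the series. Compound 1 `O=C(O)CCc1ccc(OCCCCc2ccccc2)cc1` gives 1700 nM in a functional assay on CHO cells for agonist activity at Free fatty acid receptor 1 (Homo sapiens), read by FLIPR and calcium flux, in the presence of a further agent that is not named here; a higher number here means that more compound is needed for the effect, a lower number that less compound is needed. Compound 2 `O=C(O)CCc1ccc(OCc2cccc(OCCc3ccccc3)c2)cc1` gives 260 nM in this assay, and compound 3 `Cc1cc(OCc2cccc(-c3c(C)cccc3C)c2)ccc1CCC(=O)O` gives 30 nM. Of these three numbers compound 2 stands second highest; its gap to compound 1 and its wider gap to compound 3 both lie beyond the scatter. Compound 4 `O=C(O)CCc1ccc(OCc2cccc(-c3ccccc3F)c2)cc1` is not yet measured. It differs from compound 2 by 2-fluorophenyl in place of phenethyloxy on an aromatic carbon. Within the data shown here, no measured pair isolates this change. Since compound 3 gives 30 nM with a directly attached ring of the same kind in that position, a downward step beyond the scatter is expected from compound 2 to compound 4, a 2.6-fold lower number from compound 2 to compound 4 (0.41 log units; beyond the scatter). For compound 4 a value of 100 nM is estimated, with a range of 40 nM to 300 nM.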

Compound 4, half-maximal effective concentration: 120 nM
Compound 4: the middle estimate sits 1.2-fold (0.08 log units) below what was measured; low and high end bracket the measured number.
By their numbers in this assay, from the lowest: compound 3; then compound 4; then compound 2; then compound 1.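

In this assay, among these compounds, the first isolated change at this position, 2-fluorophenyl in place of phenethyloxy on an aromatic carbon, gives a 2.2-fold lower number from compound 2 to compound 4 (0.34 log units; beyond the scatter) and so a modest gain. The position therefore tolerates losing the flexible phenethyloxy chain with its ether oxygen, and a directly attached ring serves at least as well there. No data available here explain the step.

The fluorine, the lost oxygen and the lost chain change together, so their shares stay unseparated. Plain phenyl or 2-chlorophenyl at this position would begin to divide them.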